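Bridged amino esters and cytotoxicity toward rat muscle cells

This account rests on a few compounds, and the source may have more. Where it says the series, first, only, none or still open, it means among the compounds named here.

Measured compounds:
compound 1 `CN(C)C12CC(OC(=O)CN3CCC(O)CC3)C(C(c3ccccc3)C1)C(c1ccccc1)C2`, 102000 nM
compound 2 `O=C(CN1CCC(O)CC1)OC1CC2(N3CCCC3)CC(c3ccccc3)C1C(c1ccccc1)C2`, 93400 nM
compound 3 `CN(C)C12CC(OC(=O)CCN3CCC(O)CC3)C(C(c3ccccc3)C1)C(c1ccccc1)C2`, 89200 nM

In an ADME assay on L6 cells (Rattus norvegicus) for cytotoxicity (a lower number here means a stronger inhibitor, a higher number a weaker inhibitor), compound 1 gives 102000 nM. Compound 2 differs from it by pyrrolidin-1-yl in place of dimethylamino on a saturated ring carbon, and the step is a 1.1-fold lower number from compound 1 to compound 2 (0.04 log units; within the scatter). Compound 3 differs from compound 1 by (4-hydroxypiperidin-1-yl)methyl in place of 4-hydroxypiperidin-1-yl on a saturated chain carbon bound to a carbonyl carbon, with a step of a 1.1-fold lower number from compound 1 to compound 3 (0.06 log units; within the scatter). All three numbers lie together; none of the compounds can be called weaker or stronger than another.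

Compound 4 `O=C(CCN1CCC(O)CC1)OC1CC2(N3CCCC3)CC(c3ccccc3)C1C(c1ccccc1)C2` is not yet measured. It differs from compound 3 by pyrrolidin-1-yl in place of dimethylamino on a saturated ring carbon. For the measured compounds named here, this is the same kind of change as the one from compound 1 to compound 2; around the place the only difference in wording is that the ring atom bears a large group in one case and a (((4-hydroxypiperidin-1-yl)methyl)carbonyl)oxy group in the other. Because the earlier step was a 1.1-fold lower number from compound 1 to compound 2 (0.04 log units; within the scatter), the step from compound 3 to compound 4 is expected to be a 1.0-fold lower number from compound 3 to compound 4 (0.02 log units; within the scatter). Compound 4 is therefore estimated at 85000 nM, expected between 50000 nM and 150000 nM.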

Compound 4, half-maximal inhibitory concentration: 35600 nM
The estimate for compound 4 lay 2.4-fold (0.38 log units) above the measured number; measured number outside the range, below it.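

In this assay, pyrrolidin-1-yl in place of dimethylamino gives a 2.5-fold lower number from compound 3 to compound 4 (0.40 log units; beyond the scatter), and (4-hydroxypiperidin-1-yl)methyl in place of 4-hydroxypiperidin-1-yl gives a 2.6-fold lower number from compound 2 to compound 4 (0.42 log units; beyond the scatter). Although only the later step of this pair lies beyond the scatter, the pyrrolidin-1-yl change cannot be said to differ between the two cores: the same change on two cores in this assay, a 1.1-fold lower number (0.04 log units; within the scatter) from compound 1 to compound 2 and a 2.5-fold lower number (0.40 log units; beyond the scatter) from compound 3 to compound 4, 2.3-fold (0.36 log units) apart, within the scatter of two such steps. The same holds for the chain change, so the four compounds show neither that either change depends on its core nor that it carries over unchanged: the same change on two cores in this assay, a 1.1-fold lower number (0.06 log units; within the scatter) from compound 1 to compound 3 and a 2.6-fold lower number (0.42 log units; beyond the scatter) from compound 2 to compound 4, 2.3-fold (0.36 log units) apart, within the scatter of two such steps.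

Other amines on the saturated ring carbon, such as piperidin-1-yl or morpholin-4-yl, remain open. So does a longer chain bearing the 4-hydroxypiperidin-1-yl group.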